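A few compounds are considered here, and "the series" means these few. Any claim that something is new, unique, unknown or untested is made for them only; others in the source may bear on it.

Compound 1 `Cc1cccc(Cc2cc3cc(O[C@H]4CC[C@@H](C(=O)O)CC4)ccc3n2C)c1` is the simplest member of this small set. In an assay on isolated protein for inhibition of Long-chain-fatty-acid--CoA ligase 1 (Mus musculus), read by mass spectrometry, with a stated time of 90 min, in the presence of a further agent that is not named here (on this read-out higher numbers stand for weaker inhibition and lower numbers for stronger inhibition), compound 1 gives 400 nM. Compound 2 `Cc1cccc(Cc2c(C(N)=O)c3cc(O[C@H]4CC[C@@H](C(=O)O)CC4)ccc3n2C)c1` differs from it by a carbamoyl group in place of hydrogen on an aromatic carbon of the shared core, and in this assay compound 2 gives 440 nM. Putting the carbamoyl group in produced a 1.1-fold higher number from compound 1 to compound 2 (0.04 log units; within the scatter), a difference too small to tell apart from repeat-to-repeat noise. Among the two numbers measured so far, compound 2 therefore sits alongside compound 1, the gap between them within the scatter.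

Compound 3 `Cc1cccc(Cc2c(C#N)c3cc(O[C@H]4CC[C@@H](C(=O)O)CC4)ccc3n2C)c1` carries the next variation at the same spot: cyano in place of carbamoyl on an aromatic carbon. Going by the values given here, the only measured step that touches this position is the one from hydrogen to carbamoyl, which stayed within the scatter. Among the compounds with values here, no other compound speaks to a cyano group here. The expected step is thus a 1.0-fold higher number from compound 2 to compound 3 (0.01 log units; within the scatter), with no shift beyond the scatter in either direction. Compound 3 is accordingly estimated at 450 nM, with a plausible range from 200 nM to 1000 nM in this assay.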

Compound 3, half-maximal inhibitory concentration: 600 nM
Beside the measured number, compound 3's estimate is 1.3-fold (0.12 log units) below it; low and high end bracket the measured number.
By their numbers in this assay, from the lowest: compounds 1, 2 and 3 (each within the scatter of the next).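

Replacing carbamoyl with cyano on this aromatic carbon gives a 1.4-fold higher number from compound 2 to compound 3 (0.13 log units; within the scatter), even though cyano lacks the hydrogen-bond donor that carbamoyl carries and has a triple bond in place of a double bond. Compared directly with the hydrogen-bearing parent, cyano gives a 1.5-fold higher number from compound 1 to compound 3 (0.18 log units; within the scatter), so with hydrogen, carbamoyl and cyano, three quite different substituents, this position has yet to produce a step beyond the scatter, and the earlier pair alone could show that for only one substituent. No measurement here explains why these steps stay so small.

The compounds shown leave open whether any group at this position can move the number beyond the scatter, in either direction, since all three readings so far lie within the scatter of one another. An amine, a fluorine atom or a longer alkyl chain on this carbon would test that question, and the same cyano change might also behave differently if the 3-methylbenzyl group next to it were replaced.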